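Fluoro in place of methoxy in compound 4

A few compounds are considered here, and "the series" means these few. Any claim that something is new, unique, unknown or untested is made for them only; others in the source may bear on it.

Measured in a functional assay on RS4-11 cells (Homo sapiens) for inhibition, read by CCK-8 assay, with a stated time of 48 h, tested at 20 uM; a lower number here means less inhibition of growth, a higher number more inhibition of growth at the concentration tested:
compound 1 `N#C/C(=C\c1ccccc1OS(=O)(=O)c1ccc(F)cc1)C(=O)Nc1nnc(Cc2ccc(Cl)cc2)s1` gives 64%
compound 2 `Cc1ccc(Cc2nnc(NC(=O)/C(C#N)=C/c3ccccc3OS(=O)(=O)c3ccc(C)cc3)s2)cc1` gives 66%
compound 3 `COc1ccc(S(=O)(=O)Oc2ccccc2/C=C(\C#N)C(=O)Nc2nnc(Cc3ccc(C)cc3)s2)cc1` gives 79%

Of these three, compound 3 stands highest at 79%, clear of the other two by more than the usual scatter. Compound 4 `Cc1ccc(Cc2nnc(NC(=O)/C(C#N)=C/c3ccccc3OS(=O)(=O)c3ccc(F)cc3)s2)cc1` changes it in one place: fluoro in place of methoxy on an aromatic carbon. This puts fluoro in place of methoxy on an aromatic carbon, para to a large group.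

The closest evidence is a number 13 percentage points higher from compound 2 to compound 3 (beyond the scatter), a modest step in this assay that came with methoxy in place of methyl. Losing the methoxy may therefore give that gain back. Compound 1 also carries the 4-fluorophenyl group and gives 64%, but it differs from compound 4 in another place as well. Going by the values given here, no measured pair compares fluoro with methoxy directly, so the estimate stays uncertain.

A downward step of similar modest size is expected, and the estimated change is a number 13 percentage points lower from compound 3 to compound 4 (beyond the scatter). Compound 4 is expected at about 66%, with an estimated range from 53% to 79%.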

Compound 4, percent growth inhibition at one concentration: 73%
Estimate against measurement, compound 4: 7 percentage points below; measured number inside the range.
By their numbers in this assay, from the lowest: compounds 1, 2, 4 and 3 (each within the scatter of the next, the first and the last beyond it).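

In this assay the fluoro compound cannot be told apart from either of its neighbours at this aromatic carbon: the change from methoxy gives a number 6 percentage points lower from compound 3 to compound 4 (within the scatter) and the change from methyl gives a number 7 percentage points higher from compound 2 to compound 4 (within the scatter) even though methyl and methoxy themselves differ by more than the scatter. So the earlier gain seen with methoxy does not clearly vanish when fluoro takes its place. With the 4-fluorophenyl group held constant, methyl in place of chloro elsewhere in the molecule gives a number 9 percentage points higher from compound 1 to compound 4 (within the scatter) and so shows no clear effect; no measurement here offers an explanation for any of these results.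

As far as these compounds go, whether an amine or a carboxylic acid at this carbon would keep the growth inhibition remains open. So does whether a single concentration hides differences among these compounds.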